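A few compounds are considered here, and "the series" means these few. Any claim that something is new, unique, unknown or untested is made for them only; others in the source may bear on it.

Compound 1 `CCCc1cc2ccccc2nc1-c1cc(-c2ccccc2)no1` gives 51300 nM in a functional assay on PC-3 cells (Homo sapiens) for inhibition, read by MTT assay, with a stated time of 24 h; on this read-out lower numbers stand for stronger inhibition and higher numbers for weaker inhibition. Compound 2 `CCCCc1cc2ccccc2nc1-c1cc(-c2ccccc2)no1` reaches only the assay limit of > 100000 nM in this assay. The step of an at least 1.9-fold higher number from compound 1 to compound 2 (0.28 log units; that floor lies within the scatter) corresponds to methyl in place of hydrogen on a saturated chain carbon, three bonds along the chain from an aromatic carbon. Compound 3 `CCc1cc2ccccc2nc1-c1cc(-c2ccc(C(F)(F)F)cc2)no1` likewise stops at a limit of > 100000 nM in this assay. How the core of compound 3 differs from the core of compound 1 is not broken down here. Compound 4 `CCCc1cc2ccccc2nc1-c1cc(-c2ccc(C(F)(F)F)cc2)no1` is not yet measured in this assay; it differs from compound 3 by methyl in place of hydrogen on a saturated chain carbon, two bonds along the chain from an aromatic carbon, the same kind of change as that between compound 1 and compound 2, though here the place is two bonds along the chain from an aromatic carbon rather than three. Because the limit of > 100000 nM in this assay, at which 2 of the 3 values shown sit, already holds compound 3, compound 4 is expected to sit near 120000 nM, within 40000 nM to 350000 nM. The expected step that the limit leaves unreadable from compound 3 to compound 4 rests on an at least 1.9-fold higher number from compound 1 to compound 2 (0.28 log units; that floor lies within the scatter), which pointed toward weaker inhibition.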

Compound 4, half-maximal inhibitory concentration: 33800 nM
Compound 4: the middle estimate sits 3.6-fold (0.55 log units) above what was measured; measured number below the stated range.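

Methyl in place of hydrogen on the chain gives an at least 2.9-fold lower number from compound 3 to compound 4 (0.47 log units; beyond the scatter) in this assay, so this change does not carry over in direction from the core of compound 1 to the trifluoromethyl-bearing core: the same change on two cores in this assay, an at least 1.9-fold higher number (0.28 log units; that floor lies within the scatter) from compound 1 to compound 2 and an at least 2.9-fold lower number (0.47 log units; beyond the scatter) from compound 3 to compound 4, at least 5.7-fold (0.76 log units) apart, beyond the scatter of two such steps. This does not show that the core alone decides the outcome, as the two changes stand at different places on the chain and each step has one end at a limit: the limit of > 100000 nM in this assay, at which 2 of the 4 values shown sit. With the propyl chain, trifluoromethyl in place of hydrogen on an aromatic carbon gives a 1.5-fold lower number from compound 1 to compound 4 (0.18 log units; within the scatter), so the two cores do not separate there.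

Open, from the compounds shown here alone, is how a butyl chain behaves with trifluoromethyl present. Also open, going by these compounds, is whether a methoxy group in place of trifluoromethyl would give the same chain-length pattern.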